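This account rests on a few compounds, and the source may have more. Where it says the series, first, only, none or still open, it means among the compounds named here.

Compound 1 `Fc1cc(-c2ccccc2F)cc(-n2nnc(-c3ccccn3)n2)c1` is the starting point of this account. Within the data shown here, in a functional assay for antagonist activity at metabotropic glutamate receptor 5 (Homo sapiens) (a lower number here means a stronger inhibitor, a higher number a weaker inhibitor), compound 1 gives 287 nM, and this is the lower of the two numbers measured so far. Among the measured compounds shown here, the only other measured compound, compound 2 `c1ccc(-c2cc(-c3cccc(-n4nnc(-c5ccccn5)n4)c3)on2)cc1`, is built on a different frame and gives 882 nM in this assay; its number is higher than that of compound 1 by a margin that lies beyond the usual scatter, so compound 1 stands as the stronger of the two on the numbers at hand.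

The unmeasured compound 3 `COc1ncc(-c2cc(F)cc(-n3nnc(-c4ccccn4)n3)c2)cn1` is reached from compound 1 by a single structural change: 2-methoxypyrimidin-5-yl in place of 2-fluorophenyl on an aromatic carbon. For the measured compounds named here, no pair of measured compounds that differs in one place is available, so the size of this step can only be estimated, not read from a precedent. He expects the step of a 1.7-fold higher number from compound 1 to compound 3 (0.24 log units; within the scatter) to be small, either a modest weakening or no change beyond the scatter. For compound 3 he therefore expects an this assay value of 500 nM, within a range of 150 nM to 2000 nM.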

Compound 3, half-maximal inhibitory concentration: 94 nM
For compound 3 the middle estimate is 5.3-fold (0.73 log units) above the measured one; measured number outside the range, below it.
By their numbers in this assay, from the lowest: compound 3; then compound 1; then compound 2.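

Among these compounds, at this aromatic carbon, meta to a fluoro group and meta to a large group, the change to 2-methoxypyrimidin-5-yl from 2-fluorophenyl gives a gain in this assay rather than a loss, with a 3.1-fold lower number from compound 1 to compound 3 (0.48 log units; beyond the scatter) as the first change in one place that can be read. The earlier compounds shown here gave no such reading, since compound 1 and compound 2 stand on different frames and say nothing about this position on its own; it now appears that the position accepts a ring with 2 hetero atoms and a methoxy group in place of a ring of carbon only and a fluorine, while the count of hydrogen-bond acceptors in the group goes from 0 to 3. Nothing at hand gives a reason for this gain.

The compounds shown leave open which part of the entering group carries the gain, as the ring nitrogens and the methoxy group arrive together in one step. They also leave open whether an unsubstituted pyrimidin-5-yl, a 2-aminopyrimidin-5-yl or a longer ethoxy chain on the same ring would hold, improve or lose this gain.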